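The source may report more compounds than this note shows. Statements on the series, on what has been measured and on what is new or still open speak of the compounds shown alone.

Compound 3 `CCCCCCCCCSC[C@H](NC(C)=O)C(=O)CCl` gives 7300 nM in a functional assay on NALM-6 cells (Homo sapiens) (on this read-out lower numbers stand for stronger inhibition and higher numbers for weaker inhibition), the second highest of the three numbers, set against compound 2 `CCCCCCCCSC[C@H](NC(C)=O)C(=O)CCl` at 5600 nM and compound 1 `CCCCSC[C@H](NC(C)=O)C(=O)CCl` at 41400 nM. Compound 4 `CCCCCCCCCCSC[C@H](NC(C)=O)C(=O)CCl` carries methyl in place of hydrogen on a saturated chain carbon, nine bonds along the chain from a sulfur. Within the data shown here, the steps that bear on it are the chain lengthenings: a 7.4-fold lower number from compound 1 to compound 2 (0.87 log units; beyond the scatter) and a 5.7-fold lower number from compound 1 to compound 3 (0.75 log units; beyond the scatter), both beyond the scatter, whereas the closest comparison, a 1.3-fold higher number from compound 2 to compound 3 (0.12 log units; within the scatter), stays within it. The added methyl in compound 4 matches that last step one bond further out, so a step of a 1.1-fold higher number from compound 3 to compound 4 (0.04 log units; within the scatter) in this assay is expected, meaning none beyond the scatter. Compound 4 is therefore estimated at 8000 nM, with a range from 3500 nM to 18000 nM.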

Compound 4, half-maximal inhibitory concentration: 4700 nM
The estimate for compound 4 lay 1.7-fold (0.23 log units) above the measured number; the measured number falls inside the stated range.
By their numbers in this assay, from the lowest: compounds 4, 2 and 3 (each within the scatter of the next); then compound 1.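

In this assay, the methyl added nine bonds along the chain from the sulfur gives a 1.6-fold lower number from compound 3 to compound 4 (0.19 log units; within the scatter) and the ethyl comparison gives a 1.2-fold lower number from compound 2 to compound 4 (0.08 log units; within the scatter), so compounds 2, 3 and 4 cannot be told apart and the level seen with the two shorter of these chains holds at this length. The step from the short chain, an 8.8-fold lower number from compound 1 to compound 4 (0.94 log units; beyond the scatter), stays beyond the scatter. Nothing available explains this plateau.

On these data alone, whether a longer chain stays on this plateau remains open. Also open, as far as these compounds go, is how an amine or a carboxylic acid at the chain end would read out.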